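The source may report more compounds than this note shows. Statements on the series, on what has been measured and on what is new or still open speak of the compounds shown alone.

Compound 1 `CC(=O)OCc1cccc2c1CCOC2=O` gives in an ADME assay on HepG2 2.2.15 cells (Homo sapiens) for cytotoxicity, read by MTT assay, with a stated time of 72 h (a lower number here means that less compound is tolerated, a higher number that more compound is tolerated), a limit of > 2430000 nM.
Compound 2 `CCCCCCCC(=O)OCc1cccc2c1CCOC2=O` gives in this assay a limit of > 3450000 nM.
Compound 3 `CCC(CC)C(=O)OCc1cccc2c1CCOC2=O` gives in this assay a number, 1890000 nM.

Among the three compounds measured in this assay, compound 3 is the only one with an actual number; the other two values are limits of the assay. Compound 4 `CCOCC(=O)OCc1cccc2c1CCOC2=O` has not yet been measured in this assay. It differs from compound 3 in one place: ethoxymethyl in place of pentan-3-yl on a carbonyl carbon.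

For the measured compounds named here, two measured steps bear on a change at this carbonyl carbon. The step of an at least 1.2-fold lower number from compound 1 to compound 3 (0.10 log units; that floor lies within the scatter) and the step of an at least 1.8-fold lower number from compound 2 to compound 3 (0.26 log units; that floor lies within the scatter) both start from a limit, so only a floor can be read from each, and both floors lie within the scatter. The step that the two limits leave unreadable from compound 1 to compound 2 is not readable, since both of its ends are limits. Nothing measured here therefore points to a shift beyond the scatter for a further change at this carbonyl carbon.

On that basis the step from compound 3 to compound 4 is expected to be a 1.1-fold higher number from compound 3 to compound 4 (0.02 log units; within the scatter), which amounts to no change beyond the scatter. Compound 4 is accordingly estimated to give in this assay about 2000000 nM, with a range from 800000 nM to 5000000 nM.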

Compound 4, half-maximal cytotoxic concentration: > 3680000 nM
Compound 4 ended at the assay's limit; the forecaster's own chance of this, stated with the estimate: 40%; middle value at least 1.8-fold (0.26 log units) from the limit.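

With ethoxymethyl on the carbonyl carbon, the series adds a chain that carries an oxygen, and in this assay compound 4 gives > 3680000 nM, which is a limit of the assay. The change from pentan-3-yl to ethoxymethyl is an at least 1.9-fold higher number from compound 3 to compound 4 (0.28 log units; that floor lies within the scatter), so only a floor can be read and no shift beyond the scatter is shown, leaving pentan-3-yl the only group at this place with an actual number. The steps that link compound 4 with compound 1 and with compound 2 cannot be read.

From the compounds shown here alone, how large the step from pentan-3-yl to ethoxymethyl really is remains open. The compounds shown also leave open how an amine or a carboxylic acid on this carbonyl carbon would behave in this assay.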